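Swapping Nitro for Sulfamoyl: Will the Step Repeat?

A few compounds are considered here, and "the series" means these few. Any claim that something is new, unique, unknown or untested is made for them only; others in the source may bear on it.

Of the compounds shown here, three built on one shared core have been tested in a functional assay on the whole organism (strain Wistar albino) for inhibition, with Rattus norvegicus as the target, read by paw edema, with a stated time of 1 h, at a dose of 25 mg/kg by the oral route; on this read-out lower numbers stand for less inhibition and higher numbers for more inhibition at the one dose given (going by the name of the read-out). Compound 1 `CSc1nn(-c2ccc([N+](=O)[O-])cc2)c2nc(Nc3ccccc3)n(-c3ccccc3)c(=O)c12` gives 42.1%. Compound 2 `CSc1nn(-c2ccc(S(N)(=O)=O)cc2)c2nc(Nc3ccccc3)n(-c3ccccc3)c(=O)c12`, which carries sulfamoyl in place of nitro on an aromatic carbon, gives 68.9%; the step here is a number 26.8 percentage points higher from compound 1 to compound 2 (beyond the scatter). Compound 3 `Cc1ccc(Nc2nn(-c3ccc([N+](=O)[O-])cc3)c3nc(Nc4ccccc4)n(-c4ccccc4)c(=O)c23)cc1`, whose core differs by (4-methylphenyl)amino in place of methylsulfanyl on an aromatic carbon, gives 46.6%; that step is a number 4.5 percentage points higher from compound 1 to compound 3 (within the scatter). Compound 4 `Cc1ccc(Nc2nn(-c3ccc(S(N)(=O)=O)cc3)c3nc(Nc4ccccc4)n(-c4ccccc4)c(=O)c23)cc1` has not been measured yet. It carries sulfamoyl in place of nitro on an aromatic carbon, the same change that turned compound 1 into compound 2, and the place of the change is described in the same words for both pairs. Because that earlier change produced a number 26.8 percentage points higher from compound 1 to compound 2 (beyond the scatter), the step expected here is a number 24.4 percentage points higher from compound 3 to compound 4 (beyond the scatter). For compound 4 the estimated value is 71%, with an expected range from 58% to 84%.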

Compound 4, a percentage reported as inhibition, in the whole organism at one dose (the size of the read-out at that dose, not a potency): 77%
Beside the measured number, compound 4's estimate is 6 percentage points below it; the range from low to high includes it.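

In this assay, sulfamoyl in place of nitro on the second core gives a number 30.4 percentage points higher from compound 3 to compound 4 (beyond the scatter), and this step matches the one on the first core: the same change on two cores in this assay, a number 26.8 percentage points higher (beyond the scatter) from compound 1 to compound 2 and a number 30.4 percentage points higher (beyond the scatter) from compound 3 to compound 4, 3.6 percentage points apart, within the scatter of two such steps. The swap of methylsulfanyl for (4-methylphenyl)amino gives a number 8.1 percentage points higher from compound 2 to compound 4 (within the scatter), and it also reads alike whichever group sits on the aromatic ring: the same change on two cores in this assay, a number 4.5 percentage points higher (within the scatter) from compound 1 to compound 3 and a number 8.1 percentage points higher (within the scatter) from compound 2 to compound 4, 3.6 percentage points apart, within the scatter of two such steps. These two pairs show that the sulfamoyl step carried over between these two cores, but they do not show that it would carry to any other core, or why it occurs.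

As far as these compounds go, it remains open whether a carboxylic acid in place of sulfamoyl would give a similar step. From the compounds shown here alone, it is also open whether an amine or a longer chain in place of methylsulfanyl would leave that step intact.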